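Aryl variation on the amine-bound carbon: compound 4

The source may report more compounds than this note shows. Statements on the series, on what has been measured and on what is new or still open speak of the compounds shown alone.

Measured so far in a functional assay on A2780 cells (Homo sapiens) for inhibition, read by MTT assay, with a stated time of 72 h; a higher number here means a weaker inhibitor of growth, a lower number a stronger inhibitor of growth:
compound 1 `O=S(=O)(NCCCNCc1cccc2ccccc12)c1cc(C(F)(F)F)cc(C(F)(F)F)c1`, 3100 nM
compound 2 `O=S(=O)(NCCNCc1ccc(-c2ccccc2)cc1)c1cc(C(F)(F)F)cc(C(F)(F)F)c1`, 2600 nM
compound 3 `COc1ccc(CNCCCNS(=O)(=O)c2cc(C(F)(F)F)cc(C(F)(F)F)c2)cc1OC`, 3800 nM

Compound 1 stands second highest of the three numbers. Going by the values given here, the nearest is compound 2, whose value lies within the scatter of that of compound 1; no single-point step joins these two, so their values are simply read side by side. Among the compounds with values here, the furthest is compound 3, reached by the one step that changes only the aryl on the saturated chain carbon bound to the amine nitrogen: a 1.2-fold higher number from compound 1 to compound 3 (0.09 log units; within the scatter), within the scatter.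

Compound 4 `CC(C)(C)c1ccc(CNCCCNS(=O)(=O)c2cc(C(F)(F)F)cc(C(F)(F)F)c2)cc1` is the next entry. It differs from compound 1 as follows: 4-(tert-butyl)phenyl in place of naphthalen-1-yl on a saturated chain carbon bound to an amine nitrogen.

Within the data shown here, the step from compound 1 to compound 3 is the only one bearing on this change, since it swaps the same aryl at the same place, and it moved nothing beyond the scatter. Among the measured compounds shown here, no other step on this position is known. The expectation for compound 4 in this assay is therefore a step of a 1.1-fold higher number from compound 1 to compound 4 (0.03 log units; within the scatter), that is, none beyond the scatter. Compound 4 is estimated at 3300 nM, with a range from 1600 nM to 6800 nM.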

Compound 4, concentration for 50% growth inhibition: 2900 nM
Compound 4: the middle estimate sits 1.1-fold (0.06 log units) above what was measured; the measured number falls inside the stated range.
By their numbers in this assay, from the lowest: compounds 2, 4, 1 and 3 (each within the scatter of the next).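

In this assay, a 1.1-fold lower number from compound 1 to compound 4 (0.03 log units; within the scatter) shows that, on a saturated chain carbon bound to an amine nitrogen, going from two six-membered aromatic rings to one at the same 10 heavy atoms leaves the number within the scatter. The other new step, a 1.3-fold lower number from compound 3 to compound 4 (0.12 log units; within the scatter), also stays within the scatter, so the three aryl groups compared at this place on this chain do not separate in this assay, and a second aromatic ring is not needed to hold the value. No measurement at hand bears on why these values stay together.

From the compounds shown here alone, whether a cyclohexyl group, or a phenyl carrying a carboxylic acid, would move the number beyond the scatter stays open. Going by these compounds, the effect of a longer chain also stays open, as compound 2 differs from the others in more than one place.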